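Ester chain in place of carbamoyl on the shared core

The source may hold more compounds than are shown below. What is called first, only, known or untested is meant among the compounds shown, and "the series" means these compounds.

Measured compounds:
- compound 1 `Cc1cn([C@@H]2O[C@H](CO[Si](C)(C)C(C)(C)C)[C@@]3(OS(=O)(=O)C=C3NCC(=O)O)[C@H]2O[Si](C)(C)C(C)(C)C)c(=O)n(C)c1=O`: 30000 nM
- compound 2 `Cc1cn([C@@H]2O[C@H](CO[Si](C)(C)C(C)(C)C)[C@@]3(OS(=O)(=O)C=C3NC(N)=O)[C@H]2O[Si](C)(C)C(C)(C)C)c(=O)n(C)c1=O`: 3700 nM
- compound 3 `Cc1cn([C@@H]2O[C@@H]3COC4(O)CS(=O)(=O)O[C@@]34[C@H]2O)c(=O)[nH]c1=O`: 100000 nM

In a functional assay on MT4 cells (Homo sapiens) (a higher number here means that more compound is tolerated, a lower number that less compound is tolerated), compound 2 gives 3700 nM, the lowest of the three numbers; compound 3 gives 100000 nM and sits furthest from it. For the measured compounds named here, the one step between neighbours is an 8.1-fold lower number from compound 1 to compound 2 (0.91 log units; beyond the scatter), a change that did move the number beyond the scatter. Compound 4 `COC(=O)CCNC1=CS(=O)(=O)O[C@@]12[C@@H](CO[Si](C)(C)C(C)(C)C)O[C@@H](n1cc(C)c(=O)n(C)c1=O)[C@@H]2O[Si](C)(C)C(C)(C)C` is not yet measured; it differs from compound 2 in one place: 2-(methoxycarbonyl)ethyl in place of carbamoyl on an amine nitrogen The step from compound 1 to compound 2 is the only one that bears on this change, and it runs in the opposite sense, from a chain carrying a carbonyl to carbamoyl. Reversing that sense, with a longer ester-bearing chain entering, the account expects a number for compound 4 higher than that of compound 2, estimated as a 4.1-fold higher number from compound 2 to compound 4 (0.61 log units; beyond the scatter), though the fit to compound 1 is loose. Compound 4 is therefore expected to give 15000 nM, with a range from 4000 nM to 50000 nM.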

Compound 4, half-maximal cytotoxic concentration: > 250000 nM
Compound 4: a limit, no number (the forecaster's own chance of this, stated with the estimate: 15%); middle value at least 16-fold (1.22 log units) from the limit.
By their numbers in this assay, from the lowest: compound 2; then compound 1; then compound 3. At a limit, above all of these: compound 4.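

In this assay compound 4 gives > 250000 nM, which is a limit of the assay and not a number: the limit of > 250000 nM in this assay, at which 1 of the 4 values shown sits. On an amine nitrogen whose other neighbour is the double-bonded ring carbon, 2-(methoxycarbonyl)ethyl in place of carbamoyl gives an at least 67-fold higher number from compound 2 to compound 4 (1.82 log units; beyond the scatter), so the choice of group at this position moves the number well beyond the scatter in either direction from compound 1. For the compounds shown here, the step of an at least 8.3-fold higher number from compound 1 to compound 4 (0.92 log units; beyond the scatter) shows further that two chains carrying a carbonyl do not read alike here, which the earlier compounds could not show.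

The compounds shown leave open whether the ester or the length of the chain accounts for this difference, as a methyl ester on the shorter chain and a carboxylic acid on the longer chain would separate the two. On these data alone, how a plain amine at this nitrogen would read also stays open.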